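The compounds below may be only part of what the source reports. "The series", "measured", "known", "first", "only" and "open" are said of these compounds alone.

Of the compounds shown here, three that share a core have been tested so far in a functional assay on Caco-2 cells (Homo sapiens) for inhibition, read by MTT assay, with a stated time of 48 h, tested at 10 uM; a lower number here means less inhibition of growth, a higher number more inhibition of growth at the concentration tested. Compound 1 `Cc1cc(=O)c2c(O)c(CN3CCCC3CO)c(O)c([C@H]3CCN(C)C[C@H]3O)c2o1` gives 19%, and compound 2 `Cc1oc2c([C@H]3CCN(C)C[C@H]3O)c(O)cc(O)c2c(=O)c1C(O)c1ccc(F)cc1` gives 11%. Compound 3 `CN1CC[C@H](c2c(O)cc(O)c3c(=O)cc(/C=C/c4ccccc4)oc23)[C@H](O)C1` gives 72%, the highest of the three, and its gap to each of the other two lies beyond the usual scatter. Among these three, only compound 3 carries a 2-phenylethenyl group.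

Compound 4 `CN1CC[C@H](c2c(O)cc(O)c3c(=O)cc(/C=C/c4cccc(F)c4)oc23)[C@H](O)C1` keeps that group with one small alteration, 2-phenylethenyl to 2-(3-fluorophenyl)ethenyl: fluoro in place of hydrogen on an aromatic carbon. In words, this is fluoro in place of hydrogen on an aromatic carbon. For the measured compounds named here, no two measured compounds differ in only one place, so the data give no direct guide to the size of this step. With so small a change, no step beyond the scatter is expected in this assay, and the natural starting point is compound 3 at 72%. The estimate amounts to an expected step of a number 2 percentage points lower from compound 3 to compound 4 (within the scatter), which stays within the scatter. For compound 4 the expected value is 70%, with an estimated range from 54% to 85%.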

Compound 4, percent growth inhibition at one concentration: 61%
Beside the measured number, compound 4's estimate is 9 percentage points above it, and the stated range covers the measured number.
By their numbers in this assay, from the lowest: compounds 2 and 1 (each within the scatter of the next); then compound 4; then compound 3.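

For the compounds shown here, this is the first pair of measured compounds that differ in only one place, and in this assay putting fluoro in place of hydrogen on the phenyl ring gives a number 11 percentage points lower from compound 3 to compound 4 (beyond the scatter). This place on the 2-phenylethenyl group is therefore not indifferent to change: a single added fluorine atom moves the result by more than the usual scatter, although the size of the step is modest and compound 4 still gives 61% in this assay. Nothing measured here explains the drop.

A single step cannot show whether the drop belongs to fluoro itself or to this place on the ring. Chloro, methoxy or an amine on this same carbon, or fluoro on the other carbons of the ring, would separate those two readings.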